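This account rests on a few compounds, and the source may have more. Where it says the series, first, only, none or still open, it means among the compounds named here.

Compound 1, `COc1ccc(C(=O)/C=C/c2ccc(Br)cc2)c2c1C=CC(C)(C)O2`, is one of three close relatives tested in a functional assay on HepG2 cells (Homo sapiens) for antiproliferative activity, read by MTT assay, with a stated time of 24 h; on this read-out lower numbers stand for stronger inhibition and higher numbers for weaker inhibition. In this assay compound 1 gives > 10000 nM, which is a limit of the assay rather than a measured number. Compound 2, `COc1ccc(C(=O)/C=C/c2ccc(-n3ccnc3)cc2)c2c1C=CC(C)(C)O2`, also stops at a limit in this assay, where compound 2 gives > 10000 nM. Compound 3, `COc1ccc(C(=O)/C=C/c2ccc(C(F)(F)F)cc2)c2c1C=CC(C)(C)O2`, likewise gives only a limit in this assay, where compound 3 shows > 10000 nM. The steps among these three, a step that the two limits leave unreadable from compound 1 to compound 2, a step that the two limits leave unreadable from compound 1 to compound 3 and a step that the two limits leave unreadable from compound 2 to compound 3, cannot be sized because every value rests at the limit of > 10000 nM in this assay, at which 3 of the 3 values shown sit. So compound 1 stands at the boundary of what the assay reports, and its neighbours stand there with it.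

Compound 4, `COc1ccc(C(=O)/C=C/c2ccc(Cl)c(Cl)c2)c2c1C=CC(C)(C)O2`, has not yet been measured. It differs from compound 1 in one place: 3,4-dichlorophenyl in place of 4-bromophenyl on a double-bonded chain carbon bound to a double-bonded chain carbon. Among the measured compounds shown here, none of the measured steps gives a readable size, and none of them makes a change of this kind, so there is nothing to suggest that compound 4 would move into the measurable range. The estimate for compound 4 in this assay is 15000 nM, with an expected range from 5000 nM to 50000 nM, and most probably only a limit will be reported again. The step that this estimate implies, a step that the limit leaves unreadable from compound 1 to compound 4, is expected to stay within the scatter.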

Compound 4, half-maximal inhibitory concentration: > 10000 nM
Compound 4: only a limit was reported; the forecaster's own chance of this, stated with the estimate: 80%; the middle value does not contradict the limit.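

In this assay compound 4 gives > 10000 nM, again a limit and not a number, so no size can be read for its step from compound 1, because all the values rest at one boundary: the limit of > 10000 nM in this assay, at which 4 of the 4 values shown sit.

The compounds shown leave open how far past this limit each one truly lies, and which change, if any, would bring a measurable value in this assay.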